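Swapping an Aromatic Ring for a Saturated One

This account rests on a few compounds, and the source may have more. Where it says the series, first, only, none or still open, it means among the compounds named here.

In a functional assay on MV4-11 cells (Homo sapiens) for antiproliferative activity, read by luminescence and CellTiter-Glo, with a stated time of 72 h (on this read-out higher numbers stand for weaker inhibition and lower numbers for stronger inhibition), compound 1 `Cc1ccc(Cn2nc(Nc3ccc(F)cc3)c3ccc(-c4c(C)noc4C)cc32)cc1` has the entry "not determined" (no result reported) and so offers no number. Among the measured compounds shown here, compound 2 `CNc1cc(-c2ccc3cnn(Cc4ccc(F)cc4)c3c2)cn(C)c1=O` gives 2390 nM as the only measured value, which leaves it nothing to be ranked against. For the measured compounds named here, compound 3 `CNc1cc(-c2ccc3cnn(CC4CCCCC4)c3c2)cn(C)c1=O` keeps the rest of compound 2 but carries cyclohexyl in place of 4-fluorophenyl on a saturated chain carbon bound to an aromatic nitrogen as its single change. Going by the values given here, no measured pair offers a guide, so the expected step of a 1.3-fold higher number from compound 2 to compound 3 (0.10 log units; within the scatter) is estimated to stay within the usual scatter. Compound 3 is expected at 3000 nM in a range from 1000 nM to 9000 nM on present evidence.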

Compound 3, half-maximal inhibitory concentration: 2690 nM
Compound 3: the middle estimate sits 1.1-fold (0.05 log units) above what was measured; the range from low to high includes it.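

In this assay, the change gives a 1.1-fold higher number from compound 2 to compound 3 (0.05 log units; within the scatter), so the two compounds cannot be told apart. At this position, then, a non-aromatic ring of carbon only and an aromatic ring bearing fluorine give the same result within the scatter, though this rests on a single pair. Nothing measured here offers an explanation for this. Still open, on these data alone, is whether a piperidine ring carrying an amine, a carboxylic acid, or a longer chain at this place would shift the number in either direction.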